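Compound 3 to compound 4: aryl swap in the series

A few compounds are considered here, and "the series" means these few. Any claim that something is new, unique, unknown or untested is made for them only; others in the source may bear on it.

- compound 1 `CCc1ccc(-c2nc3c(c(C)nn3-c3ccccc3)c(-c3ccccc3[N+](=O)[O-])c2C#N)cc1` gives 1200 nM
- compound 2 `CCc1ccc(-c2nc3c(c(C)nn3-c3ccccc3)c(-c3ccccc3C#N)c2C#N)cc1` gives 2400 nM
- compound 3 `Cc1ccccc1-c1nc2c(c(C)nn2-c2ccccc2)c(-c2ccccc2O)c1C#N` gives 21000 nM

In a physicochemical assay for solubility, read by spectrophotometry, in phosphate buffer, with a stated time of 18 h, at pH 7.4 (on this read-out lower numbers stand for lower solubility and higher numbers for higher solubility), compound 3 gives 21000 nM, the highest of the three numbers and beyond the scatter from both others, with compound 2 the nearest.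

Compound 4 `Cc1nn(-c2ccccc2)c2nc(-c3ccc(F)cc3)c(C#N)c(-c3ccccc3O)c12` carries 4-fluorophenyl in place of 2-methylphenyl on an aromatic carbon, ortho to a cyano group (4-fluorophenyl in place of 2-methylphenyl on an aromatic carbon).

For the measured compounds named here, only one measured step exists, a 2.0-fold higher number from compound 1 to compound 2 (0.30 log units; within the scatter), and it is cyano in place of nitro at another place. It lies within the scatter and says nothing directly about this change. Going by the values given here, no measured pair changes the group at this place, so the data give no ground for a step of any size or direction. The value of compound 3 at 21000 nM therefore serves as the anchor, and no change beyond the scatter is expected in this assay. The expected step is a 1.4-fold lower number from compound 3 to compound 4 (0.15 log units; within the scatter), a small one.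

For compound 4 the estimate is 15000 nM, with an expected range of 5000 nM to 40000 nM.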

Compound 4, solubility: 6000 nM
Compound 4: middle estimate off by 2.5-fold (0.40 log units), on the high side; the measured number falls inside the stated range.
By their numbers in this assay, from the lowest: compounds 1 and 2 (each within the scatter of the next); then compound 4; then compound 3.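

In this assay, the aryl group ortho to a cyano group is now shown to influence the read-out: 4-fluorophenyl in place of 2-methylphenyl gives a 3.5-fold lower number from compound 3 to compound 4 (0.54 log units; beyond the scatter). The two groups match in heavy atoms, hydrogen-bond donors, hydrogen-bond acceptors and net charge, so these counts do not separate them, yet the step lies beyond the scatter. Nothing measured here accounts for this step.

With a single pair at this position, the step cannot be divided between losing the methyl group and gaining the fluorine, and plain phenyl would help to separate the two. On these data alone, it also remains open how an amine or a carboxylic acid on this aryl ring would read, and whether the step would hold with a group other than 2-hydroxyphenyl elsewhere on the core.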